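The compounds below may be only part of what the source reports. "The series", "measured", "known", "first", "only" and "open" are said of these compounds alone.

Compound 1 `Cc1ccc2nc(C(=O)Nc3c(F)cc(-c4cccc(F)c4)cc3F)c(C)c(O)c2c1` is tested in a functional assay on Hep 3B2 cells (Homo sapiens) for antiproliferative activity, read by MTT assay, with a stated time of 24 h, tested at 0.41 ug/mL (on this read-out higher numbers stand for a stronger effect at the one concentration tested and lower numbers for a weaker effect), where compound 1 gives 5.25%. Two close relatives share the same core: compound 2 `Cc1c(C(=O)Nc2c(F)cc(-c3cccc(F)c3)cc2F)nc2ccc(F)cc2c1O` gives 4.85%, and compound 3 `Cc1c(C(=O)Nc2c(F)cc(-c3cccc(F)c3)cc2F)nc2ccc(OC(F)(F)F)cc2c1O` gives 5.62%. By these numbers compound 1 falls second of the three, yet every gap is small: a number 0.4 percentage points lower from compound 1 to compound 2 (within the scatter), a number 0.4 percentage points higher from compound 1 to compound 3 (within the scatter) and a number 0.8 percentage points higher from compound 2 to compound 3 (within the scatter) all sit within the scatter. Compound 4 `Cc1c(C(=O)Nc2c(F)cc(-c3cccc(F)c3)cc2F)nc2ccc(C(F)(F)F)cc2c1O` is not yet measured and differs from compound 1 in one place: trifluoromethyl in place of methyl on an aromatic carbon. Among the compounds with values here, the steps that bear on this are the swaps of the same methyl for fluoro and for trifluoromethoxy, both within the scatter, so no change beyond the scatter is expected from compound 1 to compound 4 in this assay; the expected step is a number 0.1 percentage points higher from compound 1 to compound 4 (within the scatter). Compound 4 is therefore estimated at 5.3%, within -1% to 12%.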

Compound 4, a percentage reported as inhibition, at one concentration (the size of the read-out at that concentration, not a potency): 9.38%
The estimate for compound 4 lay 4.1 percentage points below the measured number, within the range that was stated.
By their numbers in this assay, from the lowest: compounds 2, 1, 3 and 4 (each within the scatter of the next).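

In this assay, trifluoromethyl in place of methyl gives a number 4.1 percentage points higher from compound 1 to compound 4 (within the scatter) and, against the other two groups, a number 3.8 percentage points higher from compound 3 to compound 4 (within the scatter) and a number 4.5 percentage points higher from compound 2 to compound 4 (within the scatter) on the shared core. These steps are larger than the earlier ones at this position, yet methyl, fluoro, trifluoromethoxy and trifluoromethyl still cannot be told apart on this read-out. Nothing available accounts for these numbers. The compounds shown leave open whether an amine or a carboxylic acid on this aromatic carbon would give a step beyond the scatter.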